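A few compounds are considered here, and "the series" means these few. Any claim that something is new, unique, unknown or untested is made for them only; others in the source may bear on it.

Three compounds of the series share one core and differ only in the group on an aromatic carbon of the six-membered aromatic ring of carbon only: compound 1 `CC(C)(N)C(=O)N[C@H](COCc1ccccc1C(F)(F)F)c1nnnn1CCOC(=O)NCCCCO`, compound 2 `COc1ccccc1COC[C@@H](NC(=O)C(C)(C)N)c1nnnn1CCOC(=O)NCCCCO` and compound 3 `CC(C)(N)C(=O)N[C@H](COCc1ccccc1-c1cccnc1)c1nnnn1CCOC(=O)NCCCCO`. In a functional assay on cells for inhibition of growth hormone secretagogue receptor type 1 (Homo sapiens), read by FLIPR and calcium flux (a lower number here means that less compound is needed, a higher number that more compound is needed for the effect), compound 1 gives 0.72 nM, compound 2 gives 1.11 nM and compound 3 gives 1.18 nM. The numbers sit close: a 1.5-fold higher number from compound 1 to compound 2 (0.19 log units; within the scatter), a 1.6-fold higher number from compound 1 to compound 3 (0.21 log units; within the scatter) and a 1.1-fold higher number from compound 2 to compound 3 (0.03 log units; within the scatter) all fall within the scatter, so compound 3 is separated from compound 2 by the smallest and from compound 1 by the largest of these gaps, none of them meaningful. Compound 4 `Cc1noc(C)c1-c1ccccc1COC[C@@H](NC(=O)C(C)(C)N)c1nnnn1CCOC(=O)NCCCCO` exchanges the group at the same place: 3,5-dimethyl-1,2-oxazol-4-yl in place of pyridin-3-yl on an aromatic carbon. All three measured steps bear on this exchange, each swapping the group at this position, and none moved the number beyond the scatter. For compound 4 no shift beyond the scatter is therefore expected, a 1.1-fold higher number from compound 3 to compound 4 (0.04 log units; within the scatter). The estimate for compound 4 in this assay is 1.3 nM, with a range from 0.5 nM to 3.5 nM.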

Compound 4, half-maximal effective concentration: 1.04 nM
Beside the measured number, compound 4's estimate is 1.3-fold (0.10 log units) above it; the range from low to high includes it.
By their numbers in this assay, from the lowest: compounds 1, 4, 2 and 3 (each within the scatter of the next).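

In this assay, the place ortho to a large group also takes a five-membered aromatic ring with 2 hetero atoms, 3,5-dimethyl-1,2-oxazol-4-yl, with a 1.1-fold lower number from compound 3 to compound 4 (0.05 log units; within the scatter) and a 1.1-fold lower number from compound 2 to compound 4 (0.03 log units; within the scatter) and a 1.4-fold higher number from compound 1 to compound 4 (0.16 log units; within the scatter). All four groups shown at this place therefore stay within the scatter of one another. Nothing available here accounts for this flat reading. Going by these compounds, whether a carboxylic acid, an amine or a longer alkyl chain at this place would move the number beyond the scatter stays open. Also open, on these data alone, is whether this tolerance holds with the rest of the core changed.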